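The source may hold more compounds than are shown below. What is called first, only, known or untested is meant among the compounds shown, and "the series" means these compounds.

Measured compounds in a functional assay on HT-29 cells (Homo sapiens) for antiproliferative activity, read by sulforhodamine B assay, with a stated time of 72 h; on this read-out lower numbers stand for stronger inhibition and higher numbers for weaker inhibition:
- compound 1 `Cc1ccccc1NC(=S)N/N=C/c1ccc2ccccc2n1`, which gives 42300 nM
- compound 2 `CN(C)C(=S)N/N=C/c1ccc2ccccc2n1`, which gives 20 nM
- compound 3 `CN(C)C(=S)N/N=C/c1cc2cccnc2s1`, which gives 13400 nM

Among these three numbers, compound 1 stands highest, that is, it is the weakest inhibitor of the set. The nearest value is that of compound 3, and the gap between them lies beyond the usual scatter; the furthest is that of compound 2, whose number is lower by a very wide margin, so that compound 2 is the strongest of the three by any reading of the data.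

Compound 4 `S=C(N/N=C/c1ccc2ccccc2n1)Nc1ccc(Cl)cc1` has not yet been measured in this assay. It differs from compound 1 in a single place: 4-chlorophenyl in place of 2-methylphenyl on an amide-type nitrogen. Within the data shown here, no measured pair in the set isolates this kind of change, so there is no directly comparable step to lean on. The aryl-bearing compound 1 sits far from the dimethyl-bearing compound 2 on the shared core, and exchanging one aryl group for another is not expected to close that gap. The step of a 1.7-fold lower number from compound 1 to compound 4 (0.23 log units; within the scatter) is therefore expected to be small, most likely within the scatter, with only a slight lean toward a lower number. On that basis, compound 4 is estimated at 25000 nM, with a plausible range from 5000 nM to 100000 nM.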

Compound 4, half-maximal inhibitory concentration: 97200 nM
Beside the measured number, compound 4's estimate is 3.9-fold (0.59 log units) below it; the range from low to high includes it.
By their numbers in this assay, from the lowest: compound 2; then compound 3; then compound 1; then compound 4.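

In this assay, putting 4-chlorophenyl in place of 2-methylphenyl on the amide-type nitrogen gives a 2.3-fold higher number from compound 1 to compound 4 (0.36 log units; beyond the scatter), a modest step in the direction of weaker inhibition. This shows that the position, on the nitrogen attached to the thiocarbonyl carbon, is sensitive even to an exchange of one substituted phenyl group for another, since the two groups match in heavy-atom count, in having one six-membered aromatic ring of carbon only, and in their zero counts of hydrogen-bond donors and acceptors. Nothing available here accounts for the direction or the size of this step.

Among these compounds, the single step changes both the substituent and its place on the phenyl ring, so the contributions of these two changes cannot be separated. On these data alone, how 4-methylphenyl, 2-chlorophenyl or unsubstituted phenyl would read on this nitrogen remains open, as does the effect of a phenyl ring carrying an amine or a carboxylic acid.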